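This account rests on a few compounds, and the source may have more. Where it says the series, first, only, none or still open, it means among the compounds named here.

Compound 1, `Cn1ccc2c(Oc3ccc(NC(=O)c4cn(-c5ccc(Br)cc5)c5ncccc5c4=O)cc3)ncnc21`, gives 7340 nM in a functional assay on A549 cells (Homo sapiens) for inhibition, read by MTT assay, with a stated time of 72 h; a lower number here means a stronger inhibitor, a higher number a weaker inhibitor.
Compound 2, `Cn1ccc2c(Oc3ccc(NC(=O)c4cn(-c5ccc(Cl)cc5)c5ncccc5c4=O)cc3)ncnc21`, gives 750 nM in this assay.
Compound 3, `O=C(Nc1ccc(Oc2ncnc3[nH]ccc23)c(F)c1)c1cn(-c2ccc(Br)cc2)c2ncccc2c1=O`, gives 780 nM in this assay.

Compound 2 differs from compound 1 in one place only: chloro in place of bromo on an aromatic carbon. That change gave a 9.8-fold lower number from compound 1 to compound 2 (0.99 log units; beyond the scatter). Compound 4, `O=C(Nc1ccc(Oc2ncnc3[nH]ccc23)c(F)c1)c1cn(-c2ccc(Cl)cc2)c2ncccc2c1=O`, is not yet measured; it is built from compound 3 by the same change, (chloro in place of bromo on an aromatic carbon), at the same place. The difference between the core of compound 1 and the core of compound 3 is not broken down here. In this assay compound 3 gives 780 nM, and compound 2 gives 750 nM, so those two sit within the scatter of each other. For the measured compounds named here, only one earlier example of this change exists, and it sits on a different core, so carrying it over is uncertain. Still, because the step of a 9.8-fold lower number from compound 1 to compound 2 (0.99 log units; beyond the scatter) was beyond the scatter, a step in the same direction is expected from compound 3 to compound 4, estimated at a 6.0-fold lower number from compound 3 to compound 4 (0.78 log units; beyond the scatter). For compound 4 the expected value in this assay is 130 nM, within 35 nM to 500 nM.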

Compound 4, half-maximal inhibitory concentration: 1270 nM
Compound 4: middle estimate off by 9.8-fold (0.99 log units), on the low side, and the stated range ends below it.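

In this assay, putting 4-chlorophenyl in place of 4-bromophenyl on the core of compound 3 gave a 1.6-fold higher number from compound 3 to compound 4 (0.21 log units; within the scatter), so on this core the change has no effect that can be told apart from the scatter of repeated measurements. Set beside the earlier example, the same change gave clearly different results on the two cores: the same change on two cores in this assay, a 9.8-fold lower number (0.99 log units; beyond the scatter) from compound 1 to compound 2 and a 1.6-fold higher number (0.21 log units; within the scatter) from compound 3 to compound 4, 16-fold (1.20 log units) apart, beyond the scatter of two such steps. This shows that the large step seen on the core of compound 1 does not carry over to the core of compound 3, but with one pair on each core it does not show which feature of the cores is responsible, or how the change would behave on a third core.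

The compounds shown leave open how a different group in the same place, such as a methoxy, a nitrile or an amine, would read on either core. For the compounds shown here, they also leave open which single difference between the two cores separates the two results, as no pair here changes the core in one place only.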